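A few compounds are considered here, and "the series" means these few. Any claim that something is new, unique, unknown or untested is made for them only; others in the source may bear on it.

Three sulfonamides share one core and differ only in the group on the sulfonyl sulfur. Compound 1 `Cc1ccccc1S(=O)(=O)Nc1ccc2oc(-c3ccccc3)nc2c1` carries a 2-methylphenyl there, compound 2 `Cc1cccc(S(=O)(=O)Nc2ccc3oc(-c4ccccc4)nc3c2)c1` a 3-methylphenyl, and compound 3 `COc1cccc(S(=O)(=O)Nc2ccc3oc(-c4ccccc4)nc3c2)c1` a 3-methoxyphenyl. In an assay on isolated protein for inhibition of malate dehydrogenase, mitochondrial (Sus scrofa), with stated times of 45 min and 30 min (on this read-out lower numbers stand for stronger inhibition and higher numbers for weaker inhibition), compound 1 gives only a limit, > 63000 nM. Compound 2 also gives only a limit in this assay, > 63000 nM. Compound 3 too gives only a limit in this assay, > 63000 nM. Because all three values sit at the limit of > 63000 nM in this assay, at which 3 of the 3 values shown sit, none of the steps between them can be sized: a step that the two limits leave unreadable from compound 1 to compound 2, a step that the two limits leave unreadable from compound 1 to compound 3 and a step that the two limits leave unreadable from compound 2 to compound 3 are each unreadable. On the numbers shown, compound 3 thus stands where its two companions stand, at the limit of the assay.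

Compound 4 `CS(=O)(=O)Nc1ccc2oc(-c3ccccc3)nc2c1` has not been measured. Its change from compound 3 is methyl in place of 3-methoxyphenyl on a sulfonyl sulfur, so the whole aromatic piece is removed and only a methyl remains on the sulfonyl sulfur. Among the measured compounds shown here, no measured step bears on a change of this kind, and the steps among compounds 1, 2 and 3 offer no size to lean on. With the entire set at the limit, compound 4 is expected to stay there as well, and the step that the limit leaves unreadable from compound 3 to compound 4 is expected to be none beyond the scatter. The estimate for compound 4 in this assay is 100000 nM, ranging from 20000 nM to 500000 nM.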

Compound 4, half-maximal inhibitory concentration: > 63000 nM
Compound 4: a limit, no number; the forecaster's own chance of this, stated with the estimate: 85%; the middle value does not contradict the limit.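

The steps from compound 1, compound 2 and compound 3 to compound 4 cannot be read, since each joins two limits in this assay and no size comes out of them: the limit of > 63000 nM in this assay, at which 4 of the 4 values shown sit.

The compounds shown leave open which group on the sulfonyl sulfur, if any, would give a measurable number rather than a limit.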